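The compounds below may be only part of what the source reports. "The series", "measured", "known", "first", "only" and "open" are said of these compounds alone.

Compound 1 `CCN(CC)c1nc(C)c2[nH]c(SCC(=O)NCCCN)nc2n1` gives only a limit of the assay in an ADME assay on CEM174 cells (Homo sapiens) for cytotoxicity (a higher number here means that more compound is tolerated, a lower number that less compound is tolerated), namely > 100 uM.
Compound 2 `CCN(CC)CC[n+]1c(SCC(=O)NCCCN)[nH]c2c(C)nc(N(CC)CC)nc21` likewise gives only a limit in this assay, namely > 100 uM.
Compound 3 `CCN(CC)c1nc(C)c2[nH]c(SCC(=O)NCCNC(=N)N)nc2n1` also gives only a limit in this assay, namely > 100 uM.

All three measured compounds thus sit at the limit of > 100 uM in this assay, at which 3 of the 3 values shown sit. Compound 3 differs from compound 1 by a group of 4 heavy atoms (1 carbon, 3 nitrogen; no ring) in place of a group of 2 heavy atoms (1 carbon, 1 nitrogen; no ring), on a saturated chain carbon, two bonds along the chain from an amide-type nitrogen, and the resulting step that the two limits leave unreadable from compound 1 to compound 3 cannot be read because both ends are limits. Compound 2 differs from compound 1 in the core, a difference that is not broken down here. Compound 4 `CCN(CC)CC[n+]1c(SCC(=O)NCCNC(=N)N)[nH]c2c(C)nc(N(CC)CC)nc21` stands to compound 2 as compound 3 stands to compound 1: it carries a group of 4 heavy atoms (1 carbon, 3 nitrogen; no ring) in place of a group of 2 heavy atoms (1 carbon, 1 nitrogen; no ring), on a saturated chain carbon, two bonds along the chain from an amide-type nitrogen, the same change at the same place. Since compound 1 and compound 3 both sit at the limit of > 100 uM in this assay, at which 3 of the 3 values shown sit, the step from compound 2 to compound 4 in this assay is expected to be a step that the limit leaves unreadable from compound 2 to compound 4, the same unreadable kind of step. Compound 4 is therefore expected to give 150 uM, most likely again only as a limit, within 70 uM to 400 uM.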

Compound 4, half-maximal toxic concentration: > 100 uM
Compound 4 was reported as a limit; the forecaster's own chance of this, stated with the estimate: 85%; the middle value lies beyond the limit too.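

Compound 2 and compound 4 are both reported only as limits, so no step can be read between them: the limit of > 100 uM in this assay, at which 4 of the 4 values shown sit.

The compounds shown leave open what concentration of any of them is toxic in this assay, and whether the change of group shifts it.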